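The compounds below may be only part of what the source reports. "The series", "measured", "known", "first", "only" and "open" are said of these compounds alone.

In a functional assay on HEL cells (Homo sapiens) for cytotoxicity (on this read-out lower numbers stand for higher toxicity in this test and higher numbers for lower toxicity in this test), compound 1 `O=c1ccn(C2COC(CO)C(O)C2)c(=O)[nH]1` is reported only as a limit, > 50 ug/mL. Compound 2 `CCc1cn(C2COC(CO)C(O)C2)c(=O)[nH]c1=O` is likewise reported only as a limit, > 50 ug/mL. The evidence so far amounts to the limit of > 50 ug/mL in this assay, at which 2 of the 2 values shown sit. Compound 3 `O=c1[nH]c(=O)n(C2COC(CO)C(O)C2)cc1/C=C/Br` differs from compound 2 by one change: 2-bromoethenyl in place of ethyl on an aromatic carbon. Going by the values given here, the only measured step, a step that the two limits leave unreadable from compound 1 to compound 2, has no readable size, so it offers no basis for expecting a shift beyond the scatter in either direction in this assay. The expected step is a number no higher from compound 2 to compound 3 (the limit leaves the size open). Compound 3 is estimated at 50 ug/mL, with an expected range from 20 ug/mL to 100 ug/mL.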

Compound 3, half-maximal cytotoxic concentration: 50 ug/mL
The estimate for compound 3 equals the measured number at the digits printed; measured number inside the range.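

In this assay compound 3 gives 50 ug/mL, the first result at this aromatic carbon that is a number and not a limit, so with 2-bromoethenyl in this place a readable toxicity value appears. With 2-bromoethenyl in place of ethyl the result is a number no higher from compound 2 to compound 3 (the limit leaves the size open). With 2-bromoethenyl in place of hydrogen the result is a number no higher from compound 1 to compound 3 (the limit leaves the size open). Going by these compounds, neither step can be read in size, so how far this group moves the number stays unknown. Most results still sit at one edge of the test: the limit of > 50 ug/mL in this assay, at which 2 of the 3 values shown sit. Open, on these data alone, is whether an amine or a longer chain on this carbon would also give a number, and whether the bromine or the double bond matters for the value of compound 3.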